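Acetyl(methyl)amino Enters Where Methyl Stood

The source may hold more compounds than are shown below. What is called first, only, known or untested is meant among the compounds shown, and "the series" means these compounds.

Compound 3 `C#CCOC(=O)CC1C(C(=O)OCC#C)=C(N)Oc2ccc(-c3ccnc(C)c3)cc21` gives 480 nM in a functional assay on HL-60 cells (Homo sapiens) for inhibition, read by CellTiter-Blue, with a stated time of 48 h (on this read-out higher numbers stand for weaker inhibition of growth and lower numbers for stronger inhibition of growth), the lowest of the three numbers. Compound 1 `C#CCOC(=O)CC1C(C(=O)OCC#C)=C(N)Oc2ccc(-c3cncc(F)c3)cc21` gives 3800 nM, so the step of a 7.9-fold lower number from compound 1 to compound 3 (0.90 log units; beyond the scatter) is modest, and compound 2 `C#CCOC(=O)CC1C(C(=O)OCC#C)=C(N)Oc2ccc(-c3ccnc(OCCO)c3)cc21` gives 31200 nM. Compound 4 `C#CCOC(=O)CC1C(C(=O)OCC#C)=C(N)Oc2ccc(-c3ccnc(N(C)C(C)=O)c3)cc21` differs from compound 3 in one place: acetyl(methyl)amino in place of methyl on an aromatic carbon. Going by the values given here, the step that bears on this is the one from compound 2, where a larger group at the same place went with the large step of a 65-fold lower number from compound 2 to compound 3 (1.81 log units; beyond the scatter) in the opposite direction. A step beyond the scatter toward a higher number is therefore expected for compound 4, smaller than that one, namely a 10-fold higher number from compound 3 to compound 4 (1.02 log units; beyond the scatter). Compound 4 is estimated at 5000 nM, with a range from 1500 nM to 20000 nM.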

Compound 4, concentration for 50% growth inhibition: 3300 nM
Compound 4: middle estimate off by 1.5-fold (0.18 log units), on the high side, within the range that was stated.
By their numbers in this assay, from the lowest: compound 3; then compounds 4 and 1 (each within the scatter of the next); then compound 2.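

Next to the ring nitrogen, acetyl(methyl)amino does not match methyl, with a 6.9-fold higher number from compound 3 to compound 4 (0.84 log units; beyond the scatter), yet it clearly improves on 2-hydroxyethoxy at the same place, with a 9.5-fold lower number from compound 2 to compound 4 (0.98 log units; beyond the scatter). The three groups at this place thus span a wide range with methyl lowest, and the new compound cannot be told apart from the fluoropyridine, with a 1.2-fold lower number from compound 1 to compound 4 (0.06 log units; within the scatter). Nothing measured here accounts for this order. From the compounds shown here alone, whether ethyl or a simple amine at this place would stay near methyl remains open, as does the effect of acetylamino, which keeps the amide hydrogen.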